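Aziridinyl quinoline-dione series: phenyl in place of pyridin-2-yl

This account rests on a few compounds, and the source may have more. Where it says the series, first, only, none or still open, it means among the compounds named here.

Working notes on a small set of aziridine-bearing quinoline-diones tested for growth inhibition in a functional assay on cells (Cancer cell lines); a lower number here means a stronger inhibitor of growth, a higher number a weaker inhibitor of growth. Among the measured compounds shown here, compound 1 `O=C1C(N2CC2)=CC(=O)c2nc(-c3ccccn3)ccc21` gives 646 nM in this assay, the second highest of the three numbers measured so far. Its nearest neighbour is compound 3 `O=C1C=C(N2CC2)C(=O)c2nc(-c3ccccc3)ccc21`, which gives 263 nM, a gap beyond the scatter. Furthest away is compound 2 `O=C1C=C(N2CC2)C(=O)c2nc(-c3ccc4ccccc4c3)ccc21`, which gives 3470 nM in this assay, also beyond the scatter.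

The next compound, compound 4 `O=C1C(N2CC2)=CC(=O)c2nc(-c3ccccc3)ccc21`, differs from compound 1 in one place: phenyl in place of pyridin-2-yl on an aromatic carbon. For the measured compounds named here, no measured pair shows this exact change on this core, so the size of the step is open. Compound 3 also carries phenyl on the shared core and gives 263 nM, which points toward a lower number rather than a higher one. Compound 4 is therefore expected to fall at about 300 nM, within 100 nM to 1000 nM, a step of a 2.2-fold lower number from compound 1 to compound 4 (0.33 log units; beyond the scatter) estimated to be modest and beyond the scatter in the direction of stronger inhibition.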

Compound 4, concentration for 50% growth inhibition: 52.5 nM
Estimate against measurement, compound 4: 5.7-fold (0.76 log units) above; the measured number lies below the stated range.
By their numbers in this assay, from the lowest: compound 4; then compound 3; then compound 1; then compound 2.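

In this assay, among the compounds shown here, phenyl in place of pyridin-2-yl on an aromatic carbon next to the ring nitrogen gives a 12-fold lower number from compound 1 to compound 4 (1.09 log units; beyond the scatter), a large step and the first single-place comparison. The change keeps a six-membered aromatic ring at this position and removes only the ring nitrogen of the pyridin-2-yl group, so this position is highly sensitive to that one atom. Nothing available bears on why the step is so large.

From the compounds shown here alone, whether the same change moves the number as far on the core of compound 3 stays open. Also open, going by these compounds, is how this position responds to pyridin-3-yl, pyridin-4-yl or a phenyl carrying a methoxy group or a fluorine.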